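The source may hold more compounds than are shown below. What is called first, only, known or untested is meant among the compounds shown, and "the series" means these compounds.

Measured so far in a functional assay on RXF 393 cells (Homo sapiens) for inhibition, read by sulforhodamine B assay, with a stated time of 48 h; on this read-out higher numbers stand for weaker inhibition of growth and lower numbers for stronger inhibition of growth:
- compound 1, `CCOC(=O)[C@H](CCC(=O)O)NC(=O)c1ccc(Sc2nc3cc(N)cc(N)c3nc2-c2ccccc2)cc1`: 74100 nM
- compound 2, `Nc1cc(N)c2nc(-c3ccccc3)c(Oc3ccc(F)cc3)nc2c1`: < 100000 nM

Compound 2 stands only as a limit in this assay, the value < 100000 nM being a limit of the assay and not a number, so its place on the scale is not fixed; the limit of < 100000 nM in this assay, at which 1 of the 2 values shown sits, marks this. Compound 1, which carries a different aryl sulfanyl group on the shared core, gives 74100 nM in this assay, a weak inhibition of growth.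

Compound 3, `COc1ccc(Sc2nc3cc(N)cc(N)c3nc2-c2ccccc2)cc1`, is not yet measured. It differs from compound 2 as follows: (4-methoxyphenyl)sulfanyl in place of 4-fluorophenoxy on an aromatic carbon. Among the measured compounds shown here, no step between measured compounds is available for this change, so the size of the expected step rests on the two values alone. Since compound 1 with its sulfanyl-linked aryl group sits at 74100 nM, compound 3 is expected to remain in the weak range, with the step that the limit leaves unreadable from compound 2 to compound 3 expected to be small or none beyond the scatter. The estimate for compound 3 in this assay is 50000 nM, with a range from 10000 nM to 150000 nM.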

Compound 3, concentration for total growth inhibition: 17000 nM
The estimate for compound 3 lay 2.9-fold (0.47 log units) above the measured number; measured number inside the range.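

No step can be read from compound 2 to compound 3 in this assay, because compound 2 stands only as a limit: the limit of < 100000 nM in this assay, at which 1 of the 3 values shown sits.

The compounds shown leave open how large an effect on growth inhibition, if any, comes with (4-methoxyphenyl)sulfanyl in place of 4-fluorophenoxy on the shared core.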